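Removing a Methyl from Compound 1: Expected Cytotoxicity

The source may hold more compounds than are shown below. What is called first, only, known or untested is meant among the compounds shown, and "the series" means these compounds.

Measured compounds:
compound 1 `CCN(CC)C(=O)c1c(CCc2ccc3ccccc3c2)cccc1OC` — 35800 nM
compound 2 `CCN(CC)C(=O)c1c(/C=C\c2ccc3ccccc3c2)cc(OC)cc1OC` — assay limit > 100000 nM
compound 3 `Cc1cc(O)c(C(=O)O)c(CCc2ccc3ccccc3c2)c1` — 38000 nM

In an ADME assay on HepG2 cells (Homo sapiens) for cytotoxicity, read by resazurin assay, with a stated time of 24 h (on this read-out lower numbers stand for higher toxicity in this test and higher numbers for lower toxicity in this test), compound 1 gives 35800 nM. Compound 3 gives 38000 nM, which lies within the scatter of the value of compound 1, so the two cannot be told apart. Compound 2 reached only the assay limit > 100000 nM, a limit rather than a number (the limit of > 100000 nM in this assay, at which 1 of the 3 values shown sits).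

The unmeasured compound 4 `CCN(CC)C(=O)c1c(O)cccc1CCc1ccc2ccccc2c1` differs from compound 1 in one place: hydrogen in place of methyl on an oxygen on an aromatic ring. No measured pair among the shown compounds carries this change, so there is no step to lean on. The step of a 1.1-fold higher number from compound 1 to compound 4 (0.05 log units; within the scatter) is expected to stay within the scatter. Compound 4 is therefore estimated at 40000 nM, with a range from 15000 nM to 100000 nM.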

Compound 4, half-maximal cytotoxic concentration: > 100000 nM
Compound 4 ended at the assay's limit (the forecaster's own chance of this, stated with the estimate: 25%); middle value at least 2.5-fold (0.39 log units) away from the limit.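

In this assay, going from methoxy to hydroxy gives an at least 2.7-fold higher number from compound 1 to compound 4 (0.44 log units; beyond the scatter), the only single-place step among the compounds shown, so this oxygen on the aromatic ring does matter for the read-out. Compound 4 gives > 100000 nM, a limit of the assay and not a number, so the true size of the step remains unknown: the limit of > 100000 nM in this assay, at which 2 of the 4 values shown sit.

Still open, as far as these compounds go, is how a longer chain on this oxygen, such as ethoxy, would read. An amine in place of the hydroxy is equally untested among the compounds shown.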